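Oxan-4-yl amide replacing tetramethylcyclopropyl in a histamine H3 series

This account rests on a few compounds, and the source may have more. Where it says the series, first, only, none or still open, it means among the compounds named here.

Of the compounds shown here, three have been measured in an assay on CHO cells for displacement of a labelled ligand from histamine receptor H3 (Macaca mulatta); on this read-out lower numbers stand for stronger inhibition and higher numbers for weaker inhibition: compound 1 `Cc1cc(N2CCC(N3CCCC3C)C2)ccc1NC(=O)C1C(C)(C)C1(C)C` with 37.3 nM, compound 2 `CC1CCCN1C1CCN(c2ccc(NC(=O)CC3CCCC3)cc2)C1` with 3.1 nM, and compound 3 `Cc1cc(N2CC[C@H](N3CCC[C@@H]3C)C2)ccc1NC(=O)C1CCCO1` with 7.33 nM.

Compound 1 stands at the highest number of the three in this assay, beyond the scatter from both compound 3 and compound 2. Compound 4 `Cc1cc(N2CCC(N3CCCC3C)C2)ccc1NC(=O)C1CCOCC1` carries the change oxan-4-yl in place of 2,2,3,3-tetramethylcyclopropyl on a carbonyl carbon on the shared core of compound 1: a six-membered non-aromatic ring with one hetero atom and one hydrogen-bond acceptor replaces a three-membered ring of carbon only. The other amides in this set, compound 2 and compound 3, sit at lower numbers than compound 1, so the step is expected to fall in the same direction, by a 3.7-fold lower number from compound 1 to compound 4 (0.57 log units; beyond the scatter). Compound 4 is therefore estimated at 10 nM, within 3 nM to 32 nM.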

Compound 4, inhibition constant: 6.8 nM
The estimate for compound 4 lay 1.5-fold (0.17 log units) above the measured number, and the stated range covers the measured number.
By their numbers in this assay, from the lowest: compound 2; then compounds 4 and 3 (each within the scatter of the next); then compound 1.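

In this assay, going by these compounds alone, the change on this carbonyl carbon gives a 5.5-fold lower number from compound 1 to compound 4 (0.74 log units; beyond the scatter), the first step in the set that can be read in one place. It shows that 2,2,3,3-tetramethylcyclopropyl can be replaced by oxan-4-yl, with its ring oxygen and hydrogen-bond acceptor, and that the number falls beyond the scatter. No evidence is available to explain this step.

From the compounds shown here alone, the step alters ring size and brings in the oxygen together, so what each contributes remains open. A cyclohexyl or piperidin-4-yl group on the same carbonyl carbon would separate them.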